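The source may hold more compounds than are shown below. What is called first, only, known or untested is meant among the compounds shown, and "the series" means these compounds.

Compound 1 `C=CC(=O)N1C(=O)CC(c2ccc(C(F)(F)F)cc2)Sc2ccccc21` in a functional assay on NB-4 cells (Homo sapiens) for cytotoxicity, read by CCK-8 assay, with a stated time of 24 h (on this read-out lower numbers stand for stronger inhibition and higher numbers for weaker inhibition), gives 38600 nM, the second highest of the three numbers in hand. Compound 3 `C=CC(=O)N1C(=O)CC(c2ccc(C(=O)OC)cc2)Sc2ccccc21` gives 24400 nM, with a 1.6-fold lower number from compound 1 to compound 3 (0.20 log units; within the scatter). Compound 2 `C=CC(=O)N1C(=O)CC(C)Sc2ccccc21`, carrying a methyl in place of the aryl group, gives 227000 nM, which stands beyond the scatter from compound 1. Compound 4 `C=CC(=O)N1C(=O)CC(c2ccc(C#N)cc2)Sc2ccccc21` differs from compound 1 in one place: cyano in place of trifluoromethyl on an aromatic carbon. Within the data shown here, the only step that bears on this exchange is the one on the same aromatic carbon, a 1.6-fold lower number from compound 1 to compound 3 (0.20 log units; within the scatter), which stayed within the scatter, so no step beyond the scatter in this assay is expected from compound 1 to compound 4. For compound 4 the estimate is 30000 nM, with a range of 12000 nM to 75000 nM, meaning an expected 1.3-fold lower number from compound 1 to compound 4 (0.11 log units; within the scatter).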

Compound 4, half-maximal inhibitory concentration: 62400 nM
The estimate for compound 4 lay 2.1-fold (0.32 log units) below the measured number, and the stated range covers the measured number.
By their numbers in this assay, from the lowest: compounds 3, 1 and 4 (each within the scatter of the next, the first and the last beyond it); then compound 2.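

Read in this assay, cyano in place of trifluoromethyl on this aromatic carbon gives a 1.6-fold higher number from compound 1 to compound 4 (0.21 log units; within the scatter) and so adds a second group that stays level with trifluoromethyl. Among these compounds, the position still responds to the group placed there, with a 2.6-fold higher number from compound 3 to compound 4 (0.41 log units; beyond the scatter) as the first step beyond the scatter at this carbon, and the aryl group keeps its edge over methyl, with a 3.6-fold lower number from compound 2 to compound 4 (0.56 log units; beyond the scatter) even for this cyano compound. Nothing at hand speaks to the cause of these steps. Open remains how an amine or a carboxylic acid on this aromatic carbon would read, and whether a longer chain in place of 4-cyanophenyl on the saturated ring carbon would hold the step from methyl.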